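A few compounds are considered here, and "the series" means these few. Any claim that something is new, unique, unknown or untested is made for them only; others in the source may bear on it.

- compound 1 `Cc1cccc(COc2ccc(CCC(=O)O)cc2C)c1` gives < 2 L/kg
- compound 2 `Cc1ccc(Cl)c(COc2ccc(CCC(=O)O)cc2C)c1` gives < 2 L/kg
- compound 3 `Cc1cc(C)cc(COc2ccc(CCC(=O)O)cc2C)c1` gives < 2 L/kg

These three entries come from an ADME assay on the whole organism (strain C57BL/6J) for pharmacokinetics, with Mus musculus as the target (on this read-out higher numbers stand for wider distribution into tissues and lower numbers for narrower distribution), and each is a limit of the assay, not a number. In this assay compound 3 gives < 2 L/kg as a limit. It stands level with the other two measured compounds (the limit of < 2 L/kg in this assay, at which 3 of the 3 values shown sit) and so has no exact value to start from.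

Compound 4 `Cc1cc(COc2ccc(CCC(=O)O)cc2C)cc(OC(C)C)c1` differs from compound 3 at one place, with isopropoxy in place of methyl on an aromatic carbon and the rest of the structure unchanged. Two measured changes, also made on an aromatic carbon, bear on this: a step that the two limits leave unreadable from compound 1 to compound 3 is one and a step that the two limits leave unreadable from compound 1 to compound 2 is the other. Neither has a size that can be read, and neither brings in an isopropoxy, so the data offer no measured guide to this swap. No step beyond the usual scatter is therefore expected in this assay and no direction can be called. The expected step is a step that the limit leaves unreadable from compound 3 to compound 4 on this estimate. For compound 4 the estimated value is 1 L/kg with an expected range from 0.4 L/kg to 2.5 L/kg and the assay may well report only a limit again.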

Compound 4, volume of distribution at steady state: < 2 L/kg
Compound 4: no number, only a limit; the forecaster's own chance of this, stated with the estimate: 70%; the middle value is on the limit's open side.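

Compound 4 again gives only a limit in this assay, not a number, so neither its step from compound 3 nor its step from compound 1 can be read, and all the compounds shown sit together: the limit of < 2 L/kg in this assay, at which 4 of the 4 values shown sit.

The compounds shown leave open how their true volumes of distribution compare, and whether isopropoxy in place of methyl on an aromatic carbon shifts this read-out at all.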